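Swapping Butyl for Bromo: Expected Cytotoxicity Outcome

A few compounds are considered here, and "the series" means these few. Any claim that something is new, unique, unknown or untested is made for them only; others in the source may bear on it.

Measured compounds:
Compound 1, `CCCCc1ccsc1CN[C@@H]1C[C@H]2C[C@@H]([C@H]1C)C2(C)C`: 25000 nM
Compound 2, `C[C@H]1[C@H](NCc2cc(-c3ccsc3)cs2)C[C@H]2C[C@@H]1C2(C)C`: 25000 nM

In an ADME assay on MDCK cells (Canis lupus familiaris) for cytotoxicity, read by microscopy, with a stated time of 48 h (on this read-out higher numbers stand for lower toxicity in this test and lower numbers for higher toxicity in this test), compound 1 gives 25000 nM. Compound 2 gives 25000 nM in this assay. Compound 1 therefore stands level with compound 2 at the digits shown, within the usual scatter, so neither can be called the more or less toxic of the two.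

Compound 3, `C[C@H]1[C@H](NCc2sccc2Br)C[C@H]2C[C@@H]1C2(C)C`, shares the same core and differs from compound 1 by a single change: bromo in place of butyl on an aromatic carbon. For the measured compounds named here, no measured pair shows what such a change does in this assay, so the expectation rests on compound 1 alone and on the fact that the two measured compounds, which carry different groups on their sulfur-containing rings, sit at the same value. The step from compound 1 to compound 3 is expected to be no change at the digits printed from compound 1 to compound 3 (within the scatter), none beyond the scatter. Compound 3 is estimated at 25000 nM, with an expected range from 12000 nM to 50000 nM.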

Compound 3, minimum cytotoxic concentration: 50000 nM
Beside the measured number, compound 3's estimate is 2.0-fold (0.30 log units) below it; measured number inside the range.
By their numbers in this assay, from the lowest: compounds 1, 2 and 3 (each within the scatter of the next).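

At this position, on an aromatic carbon two ring bonds from the ring sulfur, bromo in place of butyl gives a 2.0-fold higher number from compound 1 to compound 3 (0.30 log units; within the scatter) in this assay and so stays within the normal spread of repeat measurements. For the compounds shown here, this is the first direct test of a single change at this place: the long butyl chain and the lone bromine atom cannot be told apart on this read-out. No measurement offered here gives a reason for this result.

On these data alone, it remains open whether a group of another kind on the same carbon, such as an amine or a carboxylic acid, would shift the number beyond the scatter. A longer chain or a ring at this place could also behave differently, so tolerance of these two groups does not extend to every substituent.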